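Compound 1 to compound 3: fluoro in place of hydroxy

The source may report more compounds than this note shows. Statements on the series, on what has been measured and on what is new or still open speak of the compounds shown alone.

Measured so far:
Compound 1 `O=C(/C=C/c1ccc(N2CCCC2)cc1)c1ccc(O)cc1`: 620 nM
Compound 2 `COc1cc(O)ccc1C(=O)/C=C/c1ccc(F)cc1`: > 25000 nM (a limit)

Among the measured compounds shown here, in a functional assay on SNU-638 cells (Homo sapiens) for cytotoxicity, read by MTT assay (a lower number here means a stronger inhibitor, a higher number a weaker inhibitor), compound 1 gives 620 nM, the only actual number so far. The result for compound 2 is a limit of the assay and not a number, > 25000 nM.

Compound 3 `O=C(/C=C/c1ccc(N2CCCC2)cc1)c1ccc(F)cc1` keeps the core of compound 1 and carries one change, fluoro in place of hydroxy on an aromatic carbon, para to a large group. For the measured compounds named here, no measured pair differs in one place only, so the data give no direct guide to the size of this step in this assay. A modest weakening, somewhat beyond the scatter, is expected, though no real change remains possible. Going by the values given here, the sole numerical anchor is compound 1 at 620 nM. The estimated change is a 2.4-fold higher number from compound 1 to compound 3 (0.38 log units; beyond the scatter). For compound 3 the expected value is 1500 nM, with an estimated range of 350 nM to 7000 nM.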

Compound 3, half-maximal inhibitory concentration: > 25000 nM
Compound 3: a limit, no number; the forecaster's own chance of this, stated with the estimate: 10%; at least 16-fold (1.22 log units) between middle value and limit.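

In this assay, among the compounds shown here, the change from 4-hydroxyphenyl to 4-fluorophenyl provides the first comparison at a single place, with an at least 40-fold higher number from compound 1 to compound 3 (1.60 log units; beyond the scatter). With the rest of the core of compound 1 unchanged, the hydroxy on this aromatic carbon cannot be replaced by fluoro without the result moving to the limit of the assay. Compound 3 gives > 25000 nM, a limit and not a number, so the step sets only a minimum and its full size cannot be read: the limit of > 25000 nM in this assay, at which 2 of the 3 values shown sit.

On these data alone, it remains open whether a group other than hydroxy, such as an amine or a carboxylic acid, could hold the value of compound 1 at this position. The compounds shown also give no single-place step anywhere else on the core of compound 1.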